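Swapping the methoxyphenyl end for a furan on the chalcone arm

The source may hold more compounds than are shown below. What is called first, only, known or untested is meant among the compounds shown, and "the series" means these compounds.

The account concerns two measured compounds and one that awaits measurement. Compound 1, `CC(=O)c1ccc(OCC(=O)Nc2ccc(C(=O)/C=C/c3ccco3)cc2)cc1`, and compound 2, `COc1ccc(/C=C/C(=O)c2ccc(NC(=O)COc3ccc(/C(C)=N\O)cc3)cc2)cc1`, were both tested in a functional assay on the whole organism (strain albino) for inhibition, with Rattus norvegicus as the target, read by paw edema, with stated times of 30 min and 2 h, at a dose of 100 mg/kg by the oral route; on this read-out lower numbers stand for less inhibition and higher numbers for more inhibition at the one dose given (going by the name of the read-out). In this assay compound 1 gives 32%, and compound 2 gives 41%. Compound 2 thus holds the higher of the two numbers, but its nearest neighbour, compound 1, sits only a little below it, and that gap lies within the usual scatter of such measurements, so the two numbers are best regarded as level.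

Compound 3, `C/C(=N/O)c1ccc(OCC(=O)Nc2ccc(C(=O)/C=C/c3ccco3)cc2)cc1`, is the next structure. It differs from compound 2 in one place: furan-2-yl in place of 4-methoxyphenyl on a double-bonded chain carbon bound to a double-bonded chain carbon. Within the data shown here, no step between measured compounds traces this exact change, so its effect is not known from the data. Since compound 1, which also carries the furan-2-yl group on the double-bonded chain, gives 32%, the change is expected to be small, a modest drop from compound 2 that likely stays within the scatter, a number 6 percentage points lower from compound 2 to compound 3 (within the scatter). Compound 3 is therefore estimated at 35%, with a range from 22% to 48%.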

Compound 3, a percentage reported as inhibition, in the whole organism at one dose (the size of the read-out at that dose, not a potency): 44%
Estimate against measurement, compound 3: 9 percentage points below, and the stated range covers the measured number.
By their numbers in this assay, from the lowest: compounds 1, 2 and 3 (each within the scatter of the next, the first and the last beyond it).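

In this assay, the exchange of the 4-methoxyphenyl group for furan-2-yl on a double-bonded chain carbon bound to a double-bonded chain carbon gives a number 3 percentage points higher from compound 2 to compound 3 (within the scatter), so this position accepts the five-membered aromatic ring in place of the six-membered one with no change that can be told from the scatter, at least with the oxime at the far end of the molecule. With the furan-2-yl group held constant, putting the oxime in place of the acetyl group on an aromatic carbon gives a number 12 percentage points higher from compound 1 to compound 3 (beyond the scatter), the only step shown that lies beyond the scatter, and it is a modest one, so among these compounds the clearer difference comes from that aromatic carbon and not from the chain end. Nothing in the available data accounts for either step.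

On these data alone, whether a thiophene ring or an unsubstituted phenyl ring on the chain carbon would match furan-2-yl remains open, as does whether a methyl ether of the oxime, an amine or a carboxylic acid on the aromatic carbon would hold the number of compound 3. As far as these compounds go, each number also comes from a single oral dose, so how the inhibition changes with dose remains open too.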